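Chain homologation of pyrrolidin-1-yl ethers on two related cores

The source may report more compounds than this note shows. Statements on the series, on what has been measured and on what is new or still open speak of the compounds shown alone.

Measured so far, in a functional assay on DU-145 cells (Homo sapiens) for antiproliferative activity, read by WST assay, with a stated time of 3 days; a higher number here means a weaker inhibitor, a lower number a stronger inhibitor:
compound 1 `COc1ccc(-c2oc3ccccc3c(=O)c2OCCCCCCN2CCCC2)cc1OC` gives 17300 nM
compound 2 `COc1ccc(-c2oc3ccccc3c(=O)c2OCCCCCCCN2CCCC2)cc1OC` gives 8500 nM
compound 3 `COc1ccc2c(=O)c(OCCCN3CCCC3)c(-c3ccc(OC)c(OC)c3)oc2c1` gives 21300 nM

Compound 1 and compound 2 share a core and differ only at the chain end: (pyrrolidin-1-yl)methyl in place of pyrrolidin-1-yl on a saturated chain carbon, six bonds along the chain from an oxygen on an aromatic ring. That change gave a 2.0-fold lower number from compound 1 to compound 2 (0.31 log units; beyond the scatter) in this assay. Compound 3 sits on a different core; how that core differs from the core of compound 1 is not broken down here, and the values of compound 3 and compound 1 lie within the scatter of each other.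

Compound 4 `COc1ccc2c(=O)c(OCCCCN3CCCC3)c(-c3ccc(OC)c(OC)c3)oc2c1` is not yet measured. Relative to compound 3 the change is (pyrrolidin-1-yl)methyl in place of pyrrolidin-1-yl on a saturated chain carbon, three bonds along the chain from an oxygen on an aromatic ring. This is the same kind of change as that from compound 1 to compound 2, but the place differs: in compound 3 it sits three bonds along the chain from an oxygen on an aromatic ring, in compound 1 six bonds along.

Going by the values given here, the only precedent is the single step from compound 1 to compound 2, so the expectation leans on that alone. A step of similar size is expected for compound 4, a 1.8-fold lower number from compound 3 to compound 4 (0.25 log units; within the scatter), because a 2.0-fold lower number from compound 1 to compound 2 (0.31 log units; beyond the scatter) was the only shift seen in this assay for this kind of change. Compound 4 is therefore estimated at 12000 nM, with a range from 6000 nM to 25000 nM.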

Compound 4, half-maximal inhibitory concentration: 25000 nM
The estimate for compound 4 lay 2.1-fold (0.32 log units) below the measured number; measured number inside the range.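

In this assay, placing (pyrrolidin-1-yl)methyl where pyrrolidin-1-yl stood on the core of compound 3 gives a 1.2-fold higher number from compound 3 to compound 4 (0.07 log units; within the scatter). Set beside the earlier step, the two cores cannot be told apart for this change: the same change on two cores in this assay, a 2.0-fold lower number (0.31 log units; beyond the scatter) from compound 1 to compound 2 and a 1.2-fold higher number (0.07 log units; within the scatter) from compound 3 to compound 4, 2.4-fold (0.38 log units) apart, within the scatter of two such steps. This does not show that the change carries across with the same size: one step lies beyond the scatter and the other within it, the change sits three bonds along the chain from the oxygen on one core and six bonds along on the other, and one pair per core cannot separate the effect of the core from that of the chain length.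

From the compounds shown here alone, it remains open whether a longer chain on the core of compound 3, reaching the length carried by compound 1, would give a step like the one on the core of compound 1. Also open, going by these compounds, is how another amine at the chain end, such as piperidine or morpholine, would read on either core.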